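This account rests on a few compounds, and the source may have more. Where it says the series, first, only, none or still open, it means among the compounds named here.

Compound 1 `COc1cc(OC)c2cc(-c3ccc(OCc4ccccc4)cc3)c(O)nc2c1`: 10000 nM
Compound 2 `COc1ccc(-c2cc3c(OC)cc(OC)cc3n(C)/c2=N\Nc2ccccc2)cc1`: 10000 nM

In a functional assay on A549 cells (Homo sapiens) for cytotoxicity, read by colorimetric assay and MTT assay (a lower number here means a stronger inhibitor, a higher number a weaker inhibitor), compound 2 gives 10000 nM, level with compound 1 at 10000 nM. The next compound, compound 3 `COc1ccc(-c2cc3c(OC)cc(OC)cc3n(C)/c2=N\Nc2ccccn2)cc1`, differs from compound 2 in one place: pyridin-2-yl in place of phenyl on an amine nitrogen. In words, pyridin-2-yl stands in place of phenyl on an amine nitrogen, and the rest of the structure is unchanged. Among the measured compounds shown here, no measured pair in this small set differs in one place only, so the data give no direct guide to the size of this change. The two compounds differ in more than one place and show no gap in this assay. The expected step of a 1.7-fold lower number from compound 2 to compound 3 (0.22 log units; within the scatter) stays within the usual scatter and leans slightly toward a stronger inhibitor, although a larger gain cannot be ruled out. For compound 3 the estimated value is 6000 nM, with an expected range of 1200 nM to 15000 nM.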

Compound 3, half-maximal inhibitory concentration: 10000 nM
Compound 3: the middle estimate sits 1.7-fold (0.22 log units) below what was measured; low and high end bracket the measured number.
By their numbers in this assay, from the lowest: compounds 1, 2 and 3 (each within the scatter of the next).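

In this assay, among the compounds shown here, pyridin-2-yl in place of phenyl on an amine nitrogen gives no change at the digits printed from compound 2 to compound 3 (within the scatter), the first comparison here between compounds that differ in one place. At this position, the swap from an all-carbon ring to one with a hetero atom, which also adds a hydrogen-bond acceptor, leaves the reading unchanged at the digits printed. Nothing available accounts for this outcome.

The compounds shown leave open whether a different group on this amine nitrogen, such as benzyl, pyrimidin-2-yl or a phenyl ring carrying a carboxylic acid, would shift the value in this assay. They also leave open whether a change elsewhere on the shared core, such as a hydroxyl or an amine in place of a methoxy group, would do so.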